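The source may hold more compounds than are shown below. What is called first, only, known or untested is meant among the compounds shown, and "the series" means these compounds.

Measured so far in a functional assay on SK-MEL-2 cells (Homo sapiens) for cytotoxicity, read by sulforhodamine B assay; a lower number here means a stronger inhibitor, a higher number a weaker inhibitor:
- Compound 1 `CC(C)Nc1nc(-c2ccccc2)nc2ccccc12`: 16.5 ug/mL
- Compound 2 `c1ccc(-c2nc(NC3CCCCC3)c3ccccc3n2)cc1`: 9.63 ug/mL
- Compound 3 `CNc1nc(-c2ccccc2)nc2ccccc12`: 24.4 ug/mL

Compound 3 carries methyl on the nitrogen and stands within the scatter of compound 1, with a 1.5-fold higher number from compound 1 to compound 3 (0.17 log units; within the scatter). It is separated from compound 2 by a 2.5-fold higher number from compound 2 to compound 3 (0.40 log units; beyond the scatter), which is modest. The remaining step in the set is a 1.7-fold lower number from compound 1 to compound 2 (0.23 log units; within the scatter).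

Compound 4 `CN(C)CCN(C)c1nc(-c2ccccc2)nc2ccccc12` differs from compound 3 by 2-(dimethylamino)ethyl in place of hydrogen on a nitrogen on an aromatic ring. Among the measured compounds shown here, no measured compound has this group or lacks the hydrogen on that nitrogen, so the steps above bear on it only loosely. All of them change a saturated group on that same nitrogen, and all are small in this assay. A small step is therefore expected, probably within the scatter. The lean toward a lower number rests only on compound 2, given a 2.5-fold higher number from compound 2 to compound 3 (0.40 log units; beyond the scatter).

The expected change is a 1.6-fold lower number from compound 3 to compound 4 (0.21 log units; within the scatter). For compound 4 the estimated value is 15 ug/mL, with an expected range of 5 ug/mL to 40 ug/mL.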

Compound 4, half-maximal inhibitory concentration: 28.9 ug/mL
Compound 4: middle estimate off by 1.9-fold (0.28 log units), on the low side, within the range that was stated.
By their numbers in this assay, from the lowest: compounds 2, 1, 3 and 4 (each within the scatter of the next, the first and the last beyond it).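

In this assay, replacing the last hydrogen on the nitrogen with 2-(dimethylamino)ethyl gives a 1.2-fold higher number from compound 3 to compound 4 (0.07 log units; within the scatter), so the earlier result, in which every compound kept that hydrogen, now extends to a fully substituted nitrogen with no step beyond the scatter from compound 3. The same holds for the change from isopropylamino (as a 1.8-fold higher number from compound 1 to compound 4 (0.24 log units; within the scatter)), whereas the change from cyclohexylamino gives a 3.0-fold higher number from compound 2 to compound 4 (0.48 log units; beyond the scatter), so compound 2 is again the compound that separates from the others, and compound 1 still does not separate from it. No data here offer an explanation for these steps.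

Still open, on these data alone, is whether 2-(dimethylamino)ethyl would read the same on a nitrogen that keeps its hydrogen rather than a methyl. Also open, as far as these compounds go, is whether a morpholine ring or a longer chain ending in a hydroxyl group at this position would fall nearer compound 2 or compound 4.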